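A few compounds are considered here, and "the series" means these few. Any claim that something is new, unique, unknown or untested is made for them only; others in the source may bear on it.

Measured compounds:
compound 1, `Cc1nc(S(C)(=O)=O)ccc1Oc1ncnc(OC2CCN(C(=O)OC3CCC3)CC2)c1F`, 13.6 nM
compound 2, `Cc1nc(S(C)(=O)=O)ccc1Oc1ncnc(OC2CCN(C(=O)SC(C)(C)C)CC2)c1F`, 4.83 nM
compound 3, `Cc1nc(S(C)(=O)=O)ccc1Oc1ncnc(OC2CCN(C(=O)C3(F)CCC3)CC2)c1F`, 24.7 nM

All three were tested in a functional assay on isolated protein for inhibition of Glucose-dependent insulinotropic receptor (Homo sapiens), read by HTRF and cAMP accumulation; on this read-out higher numbers stand for an effect only at larger amounts of compound and lower numbers for an effect already at smaller amounts. Compound 1 gives 13.6 nM there, the second highest of the three numbers. Compound 2 lies furthest from it: a 2.8-fold lower number from compound 1 to compound 2 (0.45 log units; beyond the scatter). Compound 3 lies nearest: a 1.8-fold higher number from compound 1 to compound 3 (0.26 log units; within the scatter). Between the other two, a 5.1-fold higher number from compound 2 to compound 3 (0.71 log units; beyond the scatter).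

Compound 4, `Cc1nc(S(C)(=O)=O)ccc1Oc1ncnc(OC2CCN(C(=O)C3CCCC3)CC2)c1F`, has not yet been measured. It differs from compound 1 at one place: cyclopentyl in place of cyclobutyloxy on a carbonyl carbon. For the measured compounds named here, of the measured steps, the one from compound 1 to compound 3 bears most on this, since it also replaces the cyclobutyloxy on the carbonyl carbon with a four-membered non-aromatic ring of carbon only, and it stayed within the scatter. The step from compound 2 to compound 3 concerns a sulfur-containing group and bears less. The expectation for compound 4 is therefore a change in this assay of about the same size as that from compound 1 to compound 3, that is, nothing clearly beyond the scatter, with a slight lean toward a higher number: a 1.3-fold higher number from compound 1 to compound 4 (0.12 log units; within the scatter). Compound 4 is estimated at 18 nM, with a range from 8 nM to 45 nM.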

Compound 4, half-maximal effective concentration: 72.8 nM
Beside the measured number, compound 4's estimate is 4.0-fold (0.61 log units) below it; measured number outside the range, above it.
By their numbers in this assay, from the lowest: compound 2; then compounds 1 and 3 (each within the scatter of the next); then compound 4.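

Exchanging cyclobutyloxy for cyclopentyl on a carbonyl carbon leaves the count of heavy atoms unchanged, yet in this assay it gives a 5.4-fold higher number from compound 1 to compound 4 (0.73 log units; beyond the scatter). Compound 4 also separates from the other two, with a 2.9-fold higher number from compound 3 to compound 4 (0.47 log units; beyond the scatter) and a 15-fold higher number from compound 2 to compound 4 (1.18 log units; beyond the scatter), so it has the highest number of the four, and a carbon-only ring on the carbonyl carbon does not by itself keep a compound close to compound 1, as compound 3 did. Nothing available explains this shift.

Still open, as far as these compounds go, is whether the step follows the ring size or the loss of the ring-bearing oxygen; plain cyclobutyl and cyclopentyloxy on the same carbonyl carbon would help separate the two. From the compounds shown here alone, how an amine such as dimethylamino would read at this position is also open.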